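This account rests on a few compounds, and the source may have more. Where it says the series, first, only, none or still open, it means among the compounds named here.

Measured so far in a functional assay on PC-3 cells (Homo sapiens) for cytotoxicity, read by MTT assay, with a stated time of 72 h; a lower number here means a stronger inhibitor of growth, a higher number a weaker inhibitor of growth:
Compound 1, `C[Se]/C(=N\C(=O)c1cc2ccccc2s1)NC(=O)c1cc2ccccc2s1`, gives 65600 nM.
Compound 2, `CS/C(=N\C(=O)c1cc2ccccc2s1)NC(=O)c1cc2ccccc2s1`, gives 39400 nM.
Compound 3, `CS/C(=N\C(=O)c1cc(-c2ccccc2)nc2ccccc12)NC(=O)c1cc(-c2ccccc2)nc2ccccc12`, gives > 100000 nM, which is a limit of the assay and not a number (the limit of > 100000 nM in this assay, at which 1 of the 3 values shown sits).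

Compound 1 differs from compound 2 by a group of 2 heavy atoms (1 carbon, 1 selenium; no ring) in place of a group of 2 heavy atoms (1 carbon, 1 sulfur; no ring), on a carbon with a double bond to nitrogen. That change gave a 1.7-fold higher number from compound 2 to compound 1 (0.22 log units; within the scatter). The difference between the core of compound 2 and the core of compound 3 is not broken down here.

Compound 4, `C[Se]/C(=N\C(=O)c1cc(-c2ccccc2)nc2ccccc12)NC(=O)c1cc(-c2ccccc2)nc2ccccc12`, is not yet measured. It differs from compound 3 by a group of 2 heavy atoms (1 carbon, 1 selenium; no ring) in place of a group of 2 heavy atoms (1 carbon, 1 sulfur; no ring), on a carbon with a double bond to nitrogen, the same change at the same place. Since the earlier step was a 1.7-fold higher number from compound 2 to compound 1 (0.22 log units; within the scatter), the expected step in this assay is a step that the limit leaves unreadable from compound 3 to compound 4, and it rests only on that one pair. Compound 4 is therefore expected to give about 170000 nM, most likely again reported only as a limit, with a range estimated from 100000 nM to 400000 nM.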

Compound 4, concentration for total growth inhibition: 40200 nM
Compound 4: the middle estimate sits 4.2-fold (0.63 log units) above what was measured; the whole stated range lies above it.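

In this assay, replacing methylsulfanyl with the group made of carbon and selenium gave an at least 2.4-fold lower number from compound 3 to compound 4 (0.39 log units; beyond the scatter), so the change did not carry over in the same way from one core to the other: the same change on two cores in this assay, a 1.7-fold higher number (0.22 log units; within the scatter) from compound 2 to compound 1 and an at least 2.4-fold lower number (0.39 log units; beyond the scatter) from compound 3 to compound 4, at least 4.1-fold (0.61 log units) apart, beyond the scatter of two such steps. Compound 3 gives > 100000 nM, which is a limit of the assay and not a number: the limit of > 100000 nM in this assay, at which 1 of the 4 values shown sits. These two pairs show that the outcome of this swap differed between the two cores, but they do not show why, and they cannot predict its outcome on a further core.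

The compounds shown leave open what the same swap does on other cores. They also leave open how an amine or a longer chain would behave on the carbon with a double bond to nitrogen.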